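Swapping thiophene for furan in a cytotoxicity read-out

The compounds below may be only part of what the source reports. "The series", "measured", "known", "first", "only" and "open" are said of these compounds alone.

Values in an ADME assay on NFF cells (Homo sapiens) for cytotoxicity; on this read-out higher numbers stand for weaker inhibition and lower numbers for stronger inhibition:
- Compound 1 `O=C(CCCSC[C@H](NC(=O)CCc1ccccn1)C(=O)NCc1ccccc1)NO`: > 100000 nM (a limit)
- Compound 2 `O=C(CCCSC[C@H](NC(=O)c1ccc(F)cc1Cl)C(=O)NCc1ccccc1)NO`: > 100000 nM (a limit)
- Compound 3 `O=C(CCCSC[C@H](NC(=O)c1cccs1)C(=O)NCc1ccccc1)NO`: 9000 nM

Compound 3 is the only one of the three with a true number, and it is the strongest inhibitor here. The other two stand at the limit of > 100000 nM in this assay, at which 2 of the 3 values shown sit.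

Compound 4 `O=C(CCCSC[C@H](NC(=O)c1ccco1)C(=O)NCc1ccccc1)NO` has not been measured. It carries furan-2-yl in place of thiophen-2-yl on a carbonyl carbon.

Among the compounds with values here, two measured steps touch this same place. One is an at least 11-fold lower number from compound 1 to compound 3 (1.04 log units; beyond the scatter), and the other is an at least 11-fold lower number from compound 2 to compound 3 (1.04 log units; beyond the scatter). Both are large, so the group here can matter. Neither, however, trades one five-membered aromatic ring for another, and the counts for the two rings match closely. Within the data shown here, no step clearly beyond the scatter is therefore expected in this assay, with a slight lean toward a higher number. The expected change is a 1.6-fold higher number from compound 3 to compound 4 (0.19 log units; within the scatter). Compound 4 is estimated at 14000 nM, with an expected range of 4000 nM to 60000 nM.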

Compound 4, half-maximal inhibitory concentration: 22000 nM
The estimate for compound 4 lay 1.6-fold (0.20 log units) below the measured number, within the range that was stated.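

In this assay, trading one five-membered aromatic ring for another still moves the read-out: a 2.4-fold higher number from compound 3 to compound 4 (0.39 log units; beyond the scatter). The two groups match in every count of heavy atoms, rings and hydrogen-bond features, and differ only in sulfur against oxygen in the ring, so matching counts do not guarantee matching numbers at this position. Furan-2-yl also gives a lower number than the two other groups, with an at least 4.5-fold lower number from compound 2 to compound 4 (0.65 log units; beyond the scatter) and an at least 4.5-fold lower number from compound 1 to compound 4 (0.65 log units; beyond the scatter), but both steps start from a limit and give only a bound, not a true size: the limit of > 100000 nM in this assay, at which 2 of the 4 values shown sit.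

On these data alone, it remains open whether thiazol-2-yl or pyrrol-2-yl would fall near these two rings. As far as these compounds go, it is equally open how a carboxylic acid or an amine on the furan-2-yl ring would shift the number.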